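Working notes: from compound 3 to compound 4

The source may report more compounds than this note shows. Statements on the series, on what has been measured and on what is new or still open speak of the compounds shown alone.

In a functional assay on HCT-116 cells (Homo sapiens) for antiproliferative activity, read by MTT assay, with a stated time of 48 h (on this read-out lower numbers stand for stronger inhibition and higher numbers for weaker inhibition), compound 3 `COc1cc(/C=C/C(C)=O)ccc1OCc1cn(-c2ccccc2OC)nn1` gives 25700 nM and compound 1 `COc1cc(/C=C/C(C)=O)ccc1OCc1cn(-c2c(F)cccc2F)nn1` gives 37700 nM, so the two cannot be told apart. The step between them is a 1.5-fold lower number from compound 1 to compound 3 (0.17 log units; within the scatter). In this assay compound 2 `COc1cc(/C=C/C(C)=O)ccc1OCc1cn(-c2ccccc2CO)nn1` reaches only a limit, > 100000 nM. The steps of an at least 2.6-fold higher number from compound 1 to compound 2 (0.42 log units; beyond the scatter) and an at least 3.8-fold lower number from compound 2 to compound 3 (0.59 log units; beyond the scatter) both involve the 2-(hydroxymethyl)phenyl of compound 2, and no such group is present in compound 3 or compound 4.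

Compound 4 `COc1cc(/C=C/C(C)=O)ccc1OCc1cn(-c2ccc(C)cc2)nn1` carries the change (4-methylphenyl in place of 2-methoxyphenyl on an aromatic nitrogen), that is, 4-methylphenyl in place of 2-methoxyphenyl on an aromatic nitrogen. Among the measured compounds shown here, no measured compound bears 4-methylphenyl, so the guide is indirect. For the measured compounds named here, the nearest precedent is the exchange of 2,6-difluorophenyl for 2-methoxyphenyl, a 1.5-fold lower number from compound 1 to compound 3 (0.17 log units; within the scatter), and no shift beyond the scatter is therefore expected. The expected step is a 1.2-fold higher number from compound 3 to compound 4 (0.07 log units; within the scatter). For compound 4 the estimated value is 30000 nM, with an expected range of 10000 nM to 85000 nM.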

Compound 4, half-maximal inhibitory concentration: 76600 nM
Beside the measured number, compound 4's estimate is 2.6-fold (0.41 log units) below it, within the range that was stated.
By their numbers in this assay, from the lowest: compounds 3 and 1 (each within the scatter of the next); then compound 4. At a limit, above all of these: compound 2.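

In this assay the group on the aromatic nitrogen now gives steps beyond the scatter with no hydroxymethyl involved: a 3.0-fold higher number from compound 3 to compound 4 (0.47 log units; beyond the scatter) and a 2.0-fold higher number from compound 1 to compound 4 (0.31 log units; beyond the scatter) are both of this kind. Before this, only steps touching the limit of compound 2 lay beyond the scatter, so 4-methylphenyl is the first group here to stand apart, by measured numbers, from the pair of compound 1 and compound 3. The step that rests on a limit gives only a floor: an at least 1.3-fold lower number from compound 2 to compound 4 (0.11 log units; that floor lies within the scatter) is all that can be said of it. Compound 2 stands at a limit: the limit of > 100000 nM in this assay, at which 1 of the 4 values shown sits.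

The change replaces methoxy with methyl and moves the substituent as well, and the compounds shown cannot separate the two; 2-methylphenyl and 4-methoxyphenyl would do so. Also open, from the compounds shown here alone, is how an amine or a carboxylic acid on the phenyl ring would read here.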